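This account rests on a few compounds, and the source may have more. Where it says the series, first, only, none or still open, it means among the compounds named here.

Compound 1, `CCCCc1cc2c(=O)cc(C)[nH]c2cc1OCCOc1ccccc1`, carries a hydrogen at the position that matters for this comparison. Within the data shown here, in an ADME assay on J774 cells (Mus musculus) for antiproliferative activity, with a stated time of 72 h (on this read-out higher numbers stand for an effect only at larger amounts of compound and lower numbers for an effect already at smaller amounts), compound 1 gives 28000 nM, the highest of the two numbers measured so far. Among the measured compounds shown here, the only other measured compound, compound 2, `CCCCc1cc2c(=O)c(-c3ccc(COc4ccc(OC(F)(F)F)cc4)cc3)c(C)[nH]c2cc1OCCOc1ccccc1`, has a large aromatic group in place of that hydrogen; in this assay compound 2 gives 16000 nM, a value within the usual scatter of the number for compound 1, so the two values show no difference that can be trusted.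

Compound 3, `CCCCc1cc2c(=O)c(-c3ccc(Cl)cc3C)c(C)[nH]c2cc1OCCOc1ccccc1`, has not been measured yet. It differs from compound 1 in one place: 4-chloro-2-methylphenyl in place of hydrogen on an aromatic carbon. For the measured compounds named here, since no measured pair shows what this particular group does, the expectation rests on compound 2 alone: because compound 2 gives 16000 nM with an aromatic group at the same site, a small step is expected in this assay, if any. The expected step is a 1.6-fold lower number from compound 1 to compound 3 (0.19 log units; within the scatter), none beyond the scatter. Compound 3 is therefore estimated at 18000 nM, with a range from 7000 nM to 45000 nM.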

Compound 3, half-maximal effective concentration: > 21000 nM
Compound 3 ended at the assay's limit; the forecaster's own chance of this, stated with the estimate: 10%; middle value at least 1.1-fold (0.06 log units) from the limit.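

In this assay compound 3 gives > 21000 nM, which is a limit of the assay and not a number. No step from compound 1 to compound 3 can be read from this result: the limit of > 21000 nM in this assay, at which 1 of the 3 values shown sits.

The compounds shown leave open how far, if at all, 4-chloro-2-methylphenyl in place of hydrogen on an aromatic carbon shifts the number for compound 1.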